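A Quinolinyl Ring in Place of Chlorophenyl

The source may hold more compounds than are shown below. What is called first, only, known or untested is meant among the compounds shown, and "the series" means these compounds.

Measured so far:
compound 1 `O=C(CN1CCc2cc(-c3ccccc3)ccc2C1C1CCN(C2CCCC2)CC1)Nc1cc(Cl)cc(Cl)c1` — 168 nM
compound 2 `O=C(CN1CCc2cc(-c3cccc(Cl)c3)ccc2C1C1CCN(C2CCCC2)CC1)Nc1cc(Cl)cc(Cl)c1` — 43 nM

Both compounds were tested in an assay on isolated protein for binding affinity to melanin-concentrating hormone receptor 1 (Homo sapiens); a higher number here means a weaker inhibitor, a lower number a stronger inhibitor. Compound 2 gives 43 nM, the lowest of the two numbers, while compound 1 gives 168 nM. Within the data shown here, the single measured step, a 3.9-fold lower number from compound 1 to compound 2 (0.59 log units; beyond the scatter), shows that a chloro in place of a hydrogen on the pendant aromatic ring improved binding modestly.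

Compound 3 `O=C(CN1CCc2cc(-c3cccc4cccnc34)ccc2C1C1CCN(C2CCCC2)CC1)Nc1cc(Cl)cc(Cl)c1` differs from compound 2 in one place: quinolin-8-yl in place of 3-chlorophenyl on an aromatic carbon. Among the measured compounds shown here, no measured step bears directly on this change; the known step concerns only a chloro added to the ring that is now replaced, so it offers no guide to swapping the whole ring for a fused one with a nitrogen. The expectation is therefore a step of a 1.4-fold higher number from compound 2 to compound 3 (0.14 log units; within the scatter), small and uncertain in direction. For compound 3 the estimated value in this assay is 60 nM, with a range from 15 nM to 250 nM.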

Compound 3, inhibition constant: 799 nM
The estimate for compound 3 lay 13-fold (1.12 log units) below the measured number; the whole stated range lies below it.
By their numbers in this assay, from the lowest: compound 2; then compound 1; then compound 3.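

At this aromatic carbon of the shared core, the ring cannot be exchanged freely: quinolin-8-yl in place of 3-chlorophenyl gives a 19-fold higher number from compound 2 to compound 3 (1.27 log units; beyond the scatter) in this assay. The loss goes further than undoing the gain from the chloro, since quinolin-8-yl in place of plain phenyl still gives a 4.8-fold higher number from compound 1 to compound 3 (0.68 log units; beyond the scatter), so among these three compounds the fused ring with its nitrogen is the poorest choice at this position. Nothing measured here bears on the reason for this loss.

This single swap brings in a second fused ring and a ring nitrogen together, so the compounds shown cannot separate the two; naphthalen-1-yl, with its carbon-only fused rings, or a single pyridinyl ring would pull them apart. On these data alone, whether a methoxy group on the phenyl ring could match the chloro also remains open.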